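From a fluorophenoxy to a methoxyphenylsulfanyl group

The source may report more compounds than this note shows. Statements on the series, on what has been measured and on what is new or still open speak of the compounds shown alone.

Compound 2 `Nc1cc(N)c2nc(-c3ccccc3)c(Oc3ccc(F)cc3)nc2c1` is the point of departure. In a functional assay on NCI-H23 cells (Homo sapiens) for inhibition, read by sulforhodamine B assay, with a stated time of 48 h (a higher number here means a weaker inhibitor of growth, a lower number a stronger inhibitor of growth), compound 2 gives 39800 nM, the highest of the three numbers shown, but both other compounds lie within the scatter of repeated measurements: compound 1 `Nc1cc(N)c2nc(-c3ccccc3)c(NCc3ccc(Cl)c(Cl)c3)nc2c1` gives 27500 nM and compound 3 `CCOC(=O)[C@H](CCC(=O)O)NC(=O)c1ccc(Oc2nc3cc(N)cc(N)c3nc2-c2ccccc2)cc1` gives 30200 nM, so the three cannot be put in order. The untested compound 4 `COc1ccc(Sc2nc3cc(N)cc(N)c3nc2-c2ccccc2)cc1` keeps the shared core of compound 2 and differs by a single change: (4-methoxyphenyl)sulfanyl in place of 4-fluorophenoxy on an aromatic carbon. For the measured compounds named here, no measured pair tracks this kind of change, so the expectation rests only on the spread of the three known values. The expected step in this assay is a 1.1-fold lower number from compound 2 to compound 4 (0.06 log units; within the scatter), that is, none beyond the scatter in either direction. Compound 4 is therefore estimated at 35000 nM in this assay, within a range from 12000 nM to 90000 nM.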

Compound 4, concentration for total growth inhibition: < 100000 nM
Compound 4: only a limit was reported (the forecaster's own chance of this, stated with the estimate: 10%); the middle value is on the limit's open side.
By their numbers in this assay, from the lowest: compounds 1, 3 and 2 (each within the scatter of the next).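

In this assay, for the compounds shown here, compound 4 gives only a limit of < 100000 nM and no step from compound 2 to compound 4 can be read. The compounds shown leave open whether (4-methoxyphenyl)sulfanyl in place of 4-fluorophenoxy changes growth inhibition at all.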